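The source may hold more compounds than are shown below. What is called first, only, known or untested is meant among the compounds shown, and "the series" means these compounds.

Of the compounds shown here, three sharing one core have been measured in an ADME assay on HEK293 cells (Homo sapiens) for antiproliferative activity, read by MTT assay, with a stated time of 24 h; a lower number here means a stronger inhibitor, a higher number a weaker inhibitor. Compound 1 `COc1cc(-c2cc(C(=O)/C=C/c3ccccc3)nc3cc(-c4ccccc4)nn23)cc(OC)c1OC` gives 44800 nM. Compound 2 `COc1cc(-c2cc(/C=C/C(=O)c3ccc(C)cc3)nc3cc(-c4ccccc4)nn23)cc(OC)c1OC` gives 50400 nM. Compound 3 `COc1ccc(/C=C/C(=O)c2cc(-c3cc(OC)c(OC)c(OC)c3)n3nc(-c4ccccc4)cc3n2)cc1` gives 46600 nM. Among these three numbers compound 3 stands second highest, and the steps to its neighbours are small: a 1.0-fold higher number from compound 1 to compound 3 (0.02 log units; within the scatter) and a 1.1-fold lower number from compound 2 to compound 3 (0.03 log units; within the scatter), both within the scatter.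

Compound 4 `COc1cc(/C=C/C(=O)c2cc(-c3cc(OC)c(OC)c(OC)c3)n3nc(-c4ccccc4)cc3n2)cc(OC)c1OC` differs from compound 3 in one place: 3,4,5-trimethoxyphenyl in place of 4-methoxyphenyl on a double-bonded chain carbon bound to a double-bonded chain carbon. Among the measured compounds shown here, the step that bears most on this is the one from compound 1 to compound 3, where a single methoxy entered the same phenyl ring and the number hardly moved: a 1.0-fold higher number from compound 1 to compound 3 (0.02 log units; within the scatter). Adding two more methoxy groups to that ring is therefore not expected to shift this assay beyond the scatter in either direction. For compound 4 the estimated step is a 1.0-fold higher number from compound 3 to compound 4 (0.00 log units; within the scatter). Compound 4 is thus expected to give about 47000 nM, with a range from 25000 nM to 90000 nM.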

Compound 4, half-maximal inhibitory concentration: 41000 nM
For compound 4 the middle estimate is 1.1-fold (0.06 log units) above the measured one; the range from low to high includes it.
By their numbers in this assay, from the lowest: compounds 4, 1, 3 and 2 (each within the scatter of the next).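

In this assay, among the compounds shown here, the earlier compounds showed only what a single methoxy group does on this phenyl ring, whereas compound 4 carries the full 3,4,5-trimethoxyphenyl group at the same place, on a double-bonded chain carbon bound to a double-bonded chain carbon. Enlarging the group from 8 to 12 heavy atoms and from 1 to 3 hydrogen-bond acceptors leaves the result within the scatter (a 1.1-fold lower number from compound 3 to compound 4 (0.06 log units; within the scatter)), and so does the whole change from plain phenyl (a 1.1-fold lower number from compound 1 to compound 4 (0.04 log units; within the scatter)). No measurement here offers a reason for this insensitivity.

For the compounds shown here, all the groups at this place so far are phenyl rings bearing only methoxy or methyl groups. Going by these compounds, it remains open whether a ring carrying an amine or a carboxylic acid, or a longer chain in place of the methoxy groups, would move the number beyond the scatter.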